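Swapping the benzyl halogen pattern in a cell growth inhibitor series

The compounds below may be only part of what the source reports. "The series", "measured", "known", "first", "only" and "open" are said of these compounds alone.

Of the compounds shown here, three have been measured in a functional assay on SW-620 cells (Homo sapiens) for inhibition, read by MTT assay, with a stated time of 48 h; a lower number here means a stronger inhibitor, a higher number a weaker inhibitor. Compound 1 `Cc1ccc(COc2ccc(C(=O)NC(=S)Nc3ccc(C)c(-c4nc5ccccc5[nH]4)c3)cc2)cc1` gives 60900 nM, and compound 2 `Cc1ccc(NC(=S)NC(=O)c2ccc(OCc3ccccc3Cl)cc2)cc1-c1nc2ccccc2[nH]1` gives 57100 nM. Among the measured compounds shown here, compound 3 `Cc1ccc(NC(=O)NC(=O)c2ccc(OCc3cccc(Cl)c3)cc2)cc1-c1nc2ccccc2[nH]1` gives 16000 nM, the lowest of the three numbers, and its distance from compound 2 and from compound 1 is beyond the scatter in each case; compound 3 differs from both of them in more than one place, so no single step is traced to it.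

Compound 4 `Cc1ccc(NC(=O)NC(=O)c2ccc(OCc3ccc(Cl)cc3Cl)cc2)cc1-c1nc2ccccc2[nH]1` is the next compound, and it differs from compound 3 in one place: 2,4-dichlorophenyl in place of 3-chlorophenyl on a saturated chain carbon bound to an oxygen on an aromatic ring.

For the measured compounds named here, the only measured step that touches the same place is the change from compound 1 to compound 2, where a 1.1-fold lower number from compound 1 to compound 2 (0.03 log units; within the scatter); there, one substituted benzyl group replaced another on the same saturated chain carbon bound to an oxygen on an aromatic ring, and this assay did not move beyond the scatter. On that basis no step beyond the scatter is expected here, and the step from compound 3 to compound 4 is estimated at no change at the digits printed from compound 3 to compound 4 (within the scatter). Compound 4 is therefore expected to give about 16000 nM in this assay, with a likely range from 6000 nM to 45000 nM.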

Compound 4, half-maximal inhibitory concentration: 12200 nM
Compound 4: middle estimate off by 1.3-fold (0.12 log units), on the high side; the measured number falls inside the stated range.
By their numbers in this assay, from the lowest: compounds 4 and 3 (each within the scatter of the next); then compounds 2 and 1 (each within the scatter of the next).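

In this assay, 2,4-dichlorophenyl in place of 3-chlorophenyl gives a 1.3-fold lower number from compound 3 to compound 4 (0.12 log units; within the scatter), so the extra chlorine leaves compound 3 and compound 4 indistinguishable. This extends what the earlier step at this place showed: compound 1 and compound 2 carry a thiocarbonyl where compound 3 and compound 4 carry a carbonyl, and a swap of the substituted phenyl group stays within the scatter in both settings. No accompanying data explain this result.

Every group shown at this place is a methyl- or chlorine-bearing phenyl ring, so it remains open whether an amine or a carboxylic acid on that ring would give a step beyond the scatter. No pair shown differs only in thiocarbonyl versus carbonyl, so the effect of that exchange alone cannot be read.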